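Removing a fluorine from a weakly active sulfone

The source may hold more compounds than are shown below. What is called first, only, known or untested is meant among the compounds shown, and "the series" means these compounds.

Compound 2 `CC(O)(CS(=O)(=O)c1ccc(F)cc1)c1nc(-c2ccc(Cl)cc2)no1` carries a sulfone linking the central chain to a 4-fluorophenyl group. In a functional assay on DU-145 cells (Homo sapiens) for cytotoxicity, read by MTT assay (on this read-out higher numbers stand for weaker inhibition and lower numbers for stronger inhibition), compound 2 reaches only the limit of the method, > 100000 nM, and no number is known for it. The other measured member, compound 1 `CC(O)(CSc1ccccc1)c1nc(-c2ccc(F)c(Cl)c2)no1`, differs in several places at once; in this assay compound 1 gives 5500 nM. Compound 3 `CC(O)(CS(=O)(=O)c1ccccc1)c1nc(-c2ccc(Cl)cc2)no1` is compound 2 with one change: hydrogen in place of fluoro on an aromatic carbon, the site sitting para to a large group, so that the 4-fluorophenyl becomes a plain phenyl. Within the data shown here, no measured pair shows what this change does here, and one fluorine is a small alteration. The step from compound 2 to compound 3 is therefore expected to stay within the usual scatter, a number no higher from compound 2 to compound 3 (the limit leaves the size open), with a fair chance that the assay again reports only a limit. Compound 3 is estimated at 100000 nM, within 30000 nM to 300000 nM.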

Compound 3, half-maximal inhibitory concentration: > 100000 nM
Compound 3: only a limit was reported; the forecaster's own chance of this, stated with the estimate: 65%; the middle value lies on the limit itself.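

No step can be read from compound 2 to compound 3, because each of them gives only a limit in this assay, not a number: the limit of > 100000 nM in this assay, at which 2 of the 3 values shown sit.

The compounds shown leave open what replacing 4-fluorophenyl with phenyl does, and which of the several differences from compound 1 matters.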